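The source may report more compounds than this note shows. Statements on the series, on what has been measured and on what is new or still open speak of the compounds shown alone.

Among the compounds with values here, compound 1 `CCCCn1c(Cc2cc(OC)c(OC)c(OC)c2)nc2c(N)nc(F)nc21` gives 24000 nM in a functional assay on MCF7 cells (Homo sapiens) for antiproliferative activity (on this read-out higher numbers stand for weaker inhibition and lower numbers for stronger inhibition), the lowest of the three numbers so far. Compound 2 `CC/C=C\Cn1c(Cc2cc(OC)c(OC)c(OC)c2)nc2c(N)ncnc21` gives 64600 nM in this assay, and compound 3 `CC/C=C/Cn1c(Cc2cc(OC)c(OC)c(OC)c2)nc2c(N)ncnc21` gives 46800 nM. Against compound 3 the gap from compound 1 stays within the scatter; only against compound 2 does it reach beyond it. Within the data shown here, the single measured step, a 1.4-fold lower number from compound 2 to compound 3 (0.14 log units; within the scatter), accords with the fact that compounds 2 and 3 differ only in the configuration as drawn and offers no lever on the chain's length or saturation.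

Compound 4 `C=CCCCn1c(Cc2cc(OC)c(OC)c(OC)c2)nc2c(N)nc(F)nc21` differs from compound 1 by vinyl in place of methyl on a saturated chain carbon, three bonds along the chain from an aromatic nitrogen. Among the measured compounds shown here, no measured pair isolates this change; compounds 2 and 3 carry an unsaturated chain, but both also lack the fluorine on the core of compound 1, so their numbers cannot be read as a step for the unsaturation alone. The expectation is therefore a step of a 1.0-fold higher number from compound 1 to compound 4 (0.02 log units; within the scatter), within the scatter. Compound 4 is expected to give 25000 nM in this assay, between 10000 nM and 60000 nM.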

Compound 4, half-maximal inhibitory concentration: 44700 nM
Estimate against measurement, compound 4: 1.8-fold (0.25 log units) below; low and high end bracket the measured number.
By their numbers in this assay, from the lowest: compounds 1, 4, 3 and 2 (each within the scatter of the next, the first and the last beyond it).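

Vinyl in place of methyl on a saturated chain carbon, three bonds along the chain from an aromatic nitrogen, can now be read with the fluorine on the core kept in place, which compounds 2 and 3 could not offer: in this assay the change gives a 1.9-fold higher number from compound 1 to compound 4 (0.27 log units; within the scatter) for this butyl to pent-4-en-1-yl exchange. This chain position therefore takes the added carbon and double bond without a step beyond the scatter, so the measured pair gives no sign that unsaturation here matters on this read-out. Nothing on hand accounts for the size of this step.

Among the compounds shown, no pair isolates the fluorine on the core. Also open, going by these compounds, is whether an amine, a carboxylic acid or a longer chain in place of the butyl chain of compound 1 would give a step beyond the scatter.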